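Methoxy for fluoro on the aryl amine: cytotoxicity expected unchanged

The compounds below may be only part of what the source reports. "The series", "measured", "known", "first", "only" and "open" are said of these compounds alone.

Measured compounds:
compound 1 `COc1cc(/C=C/C(=O)/C=C(\Nc2ccc(F)cc2)SC)cc(OC)c1OC`, 43400 nM in an ADME assay on Vero cells (Chlorocebus sabaeus) for cytotoxicity, read by MTT assay, with a stated time of 72 h; on this read-out lower numbers stand for higher toxicity in this test and higher numbers for lower toxicity in this test
compound 2 `COc1cc(/C=C/C(=O)/C=C(\Nc2ccccc2)SC)cc(OC)c1OC`, 64600 nM
compound 3 `COc1cc(/C=C/C(=O)/C=C(\NCc2ccccc2)SC)cc(OC)c1OC`, 71500 nM

Compound 1 gives the lowest of the three numbers in this assay; its nearest neighbour is compound 2 at a 1.5-fold higher number from compound 1 to compound 2 (0.17 log units; within the scatter), and compound 3 lies at a 1.6-fold higher number from compound 1 to compound 3 (0.22 log units; within the scatter). Both steps sit within the scatter, as does a 1.1-fold higher number from compound 2 to compound 3 (0.04 log units; within the scatter). Compound 4 `COc1ccc(N/C(=C\C(=O)/C=C/c2cc(OC)c(OC)c(OC)c2)SC)cc1` differs from compound 1 by methoxy in place of fluoro on an aromatic carbon. Among the compounds with values here, no measured pair exchanges fluoro for methoxy, so only the aryl-amine variations bear on it, and none of them moved the read-out beyond the scatter. Compound 4 is therefore expected to stay close to compound 1, with a step of a 1.2-fold higher number from compound 1 to compound 4 (0.06 log units; within the scatter). The estimate for compound 4 is 50000 nM, ranging from 25000 nM to 100000 nM.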

Compound 4, half-maximal cytotoxic concentration: 184000 nM
Compound 4: middle estimate off by 3.7-fold (0.57 log units), on the low side; measured number above the stated range.
By their numbers in this assay, from the lowest: compounds 1, 2 and 3 (each within the scatter of the next); then compound 4.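

In this assay this position proves able to move the read-out: methoxy in place of fluoro gives a 4.2-fold higher number from compound 1 to compound 4 (0.63 log units; beyond the scatter) and methoxy in place of hydrogen gives a 2.8-fold higher number from compound 2 to compound 4 (0.45 log units; beyond the scatter) on the same aromatic carbon, whereas hydrogen in place of fluoro had stayed within the scatter. The 4-methoxyphenyl group also separates from benzyl on the amine nitrogen, with a 2.6-fold higher number from compound 3 to compound 4 (0.41 log units; beyond the scatter) in the same direction. Nothing measured here explains the shift.

Going by these compounds, whether it is specific to methoxy remains open, since an ethoxy, a hydroxyl or a dimethylamino group on that carbon could tell. So does whether a methoxy on the benzyl ring would give the same step.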